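A few compounds are considered here, and "the series" means these few. Any claim that something is new, unique, unknown or untested is made for them only; others in the source may bear on it.

Series notes. Compound 1 `COc1cc(-c2nnc(SCC(=O)c3ccc(Cl)cc3)n2N)cc(OC)c1OC` carries the shared core with a 4-chlorophenyl on the carbonyl carbon. In a functional assay on HepG2 cells (Homo sapiens) for antiproliferative activity, read by MTT assay, with a stated time of 48 h (on this read-out higher numbers stand for weaker inhibition and lower numbers for stronger inhibition), compound 1 gives > 100000 nM, which is a limit of the assay and not a number. For the measured compounds named here, compound 2 `COc1cc(-c2nnc(SCC(=O)c3ccc(Br)cc3)n2N)cc(OC)c1OC` has bromo in place of chloro on an aromatic carbon, and in this assay compound 2 gives 92500 nM, the only number in the set. Compound 3 `COc1cc(-c2nnc(SCC(=O)c3ccc(F)c(F)c3)n2N)cc(OC)c1OC` in this assay gives > 100000 nM, again a limit. Going by the values given here, compound 1 and compound 3 both sit at the limit of > 100000 nM in this assay, at which 2 of the 3 values shown sit, so compound 2 stands alone as the one readable value, and its two further neighbours show only limits.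

The steps that can be read are an at least 1.0-fold lower number from compound 1 to compound 2 (0.03 log units; that floor lies within the scatter) and an at least 1.0-fold higher number from compound 2 to compound 3 (0.03 log units; that floor lies within the scatter); a step that the two limits leave unreadable from compound 1 to compound 3 stays unreadable. Neither bearing step touches a methoxy group.

Compound 4 `COc1ccc(C(=O)CSc2nnc(-c3cc(OC)c(OC)c(OC)c3)n2N)cc1` is not yet measured. It differs from compound 2 by methoxy in place of bromo on an aromatic carbon. Given that both bearing steps have floors within the scatter, the expected step is a 1.0-fold higher number from compound 2 to compound 4 (0.01 log units; within the scatter), nothing beyond the scatter. Compound 4 is estimated at 95000 nM, with a range from 40000 nM to 200000 nM, and a real chance that only a limit is returned.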

Compound 4, half-maximal inhibitory concentration: > 100000 nM
Compound 4 was reported as a limit; the forecaster's own chance of this, stated with the estimate: 50%; middle value at least 1.0-fold (0.02 log units) from the limit.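

In this assay compound 4 gives > 100000 nM, which is a limit of the assay and not a number. Replacing bromo with methoxy, para to a large group, gives an at least 1.0-fold higher number from compound 2 to compound 4 (0.03 log units; that floor lies within the scatter), so this position has now taken a hydrogen-bond acceptor in place of a halogen without any step shown beyond the scatter. The steps that link compound 4 with compound 1 and compound 3 cannot be read, and the series now gathers at one end of the read-out: the limit of > 100000 nM in this assay, at which 3 of the 4 values shown sit.

From the compounds shown here alone, what remains open is whether any group at this position can bring the series well into the readable range. An amine or a carboxylic acid here, or a longer chain in place of methoxy, would put that question to the test.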